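Swapping a Methyl for Fluorine on a Mitochondrial Activator

The source may hold more compounds than are shown below. What is called first, only, known or untested is meant among the compounds shown, and "the series" means these compounds.

Of the compounds shown here, two sharing one core have been measured in an assay on mitochondria from L6 cells (Rattus norvegicus) for activation, with a stated time of 90 min; on this read-out lower numbers stand for an effect already at smaller amounts and higher numbers for an effect only at larger amounts of compound. Compound 1 `CCCCOc1ccc(Nc2nc3nonc3nc2O)cc1` gives 3700 nM in this assay. Compound 2 `Cc1ccc(C(F)(F)F)cc1Nc1nc2nonc2nc1O`, which carries a methyl group and a trifluoromethyl group, gives 32800 nM in this assay, the highest of the two numbers; compound 1 sits at a lower number, and that gap lies beyond the usual scatter. Compound 3 `Oc1nc2nonc2nc1Nc1cc(C(F)(F)F)ccc1F` has not yet been measured. It differs from compound 2 by fluoro in place of methyl on an aromatic carbon. Among the compounds with values here, no measured pair shows the effect of such an exchange, so the data give no direct guide. Without such a guide, the step is expected to stay within the scatter, with no clear direction, a 1.2-fold lower number from compound 2 to compound 3 (0.07 log units; within the scatter). Compound 3 is therefore estimated at 28000 nM in this assay, with a range from 9000 nM to 90000 nM.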

Compound 3, half-maximal effective concentration: 5100 nM
Compound 3: middle estimate off by 5.5-fold (0.74 log units), on the high side; measured number outside the range, below it.
By their numbers in this assay, from the lowest: compounds 1 and 3 (each within the scatter of the next); then compound 2.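

At this position, ortho to a large group and para to a trifluoromethyl group, the exchange of methyl for fluoro is far from neutral: in this assay it gives a 6.4-fold lower number from compound 2 to compound 3 (0.81 log units; beyond the scatter). Each group counts as a single heavy atom, and neither brings a ring, a hydrogen-bond donor or acceptor, or a net charge, so even a small exchange at this place can move the number beyond the usual scatter. No available measurement explains why the number drops.

As far as these compounds go, whether this drop is particular to fluoro remains open, since a plain hydrogen, a chlorine, a methoxy group or an amine at the same place could show whether other small groups give similar numbers. From the compounds shown here alone, it also remains open whether the same exchange would have a similar effect at another place on this ring.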